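Adding a second chloro to the aryl ring of compound 3

A few compounds are considered here, and "the series" means these few. Any claim that something is new, unique, unknown or untested is made for them only; others in the source may bear on it.

Compound 1 `N#C/C(=C\N1CCN(C(=O)c2ccco2)C1=S)C(=O)Nc1ccc(Cl)cc1` gives 18400 nM in a functional assay on MDA-MB-231 cells (Homo sapiens) for inhibition, read by sulforhodamine B assay, with a stated time of 48 h; a lower number here means a stronger inhibitor of growth, a higher number a weaker inhibitor of growth; compound 2 `N#C/C(=C\N1CCN(C(=O)c2ccco2)C1=S)C(=O)c1ccccc1` gives 13700 nM. Among the measured compounds shown here, the only single-point step, a 1.3-fold lower number from compound 1 to compound 2 (0.13 log units; within the scatter), lies within the scatter. Compound 3 `O=CN1CCN(c2ccc(Cl)cc2)C1=S` gives 16400 nM and stands second highest of the three, with every gap to the other two within the scatter. Compound 4 `O=CN1CCN(c2ccc(Cl)c(Cl)c2)C1=S` differs from compound 3 by chloro in place of hydrogen on an aromatic carbon. For the measured compounds named here, no measured step covers a chloro for hydrogen exchange on the aromatic ring, and the one known step did not move beyond the scatter, so no step beyond the scatter is expected here either. Compound 4 is estimated at 14000 nM, range 5000 nM to 40000 nM, meaning an expected 1.2-fold lower number from compound 3 to compound 4 (0.07 log units; within the scatter).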

Compound 4, concentration for 50% growth inhibition: 14600 nM
Compound 4: middle estimate off by 1.0-fold (0.02 log units), on the low side; the measured number falls inside the stated range.
By their numbers in this assay, from the lowest: compounds 2, 4, 3 and 1 (each within the scatter of the next).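

A chloro in place of hydrogen on the aromatic carbon ortho to the chloro group gives a 1.1-fold lower number from compound 3 to compound 4 (0.05 log units; within the scatter) in this assay. Among the compounds shown here, this is the first measured step on this aromatic ring, and it shows that a second chloro at this position does not separate compound 4 from compound 3. No evidence is available on the reason for this result.

As far as these compounds go, whether a methoxy group or an amine on this aromatic carbon would give a step beyond the scatter remains open. So does whether a carboxylic acid there would do so.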